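The source may hold more compounds than are shown below. What is called first, only, known or untested is meant among the compounds shown, and "the series" means these compounds.

In a functional assay on A2780 cells (Homo sapiens) for inhibition (a lower number here means a stronger inhibitor, a higher number a weaker inhibitor), compounds sharing one core have been compared at a single place, a saturated chain carbon bound to an aromatic carbon, and compound 1 `CCNC(=O)c1noc(-c2cc(C(C)C)c(O)cc2O)c1-c1cc(CO)no1`, which carries hydroxy there, gives 5 nM. The entry for compound 2 `CCNC(=O)c1noc(-c2cc(C(C)C)c(O)cc2O)c1-c1cc(COCC(N)=O)no1` reads "not determined" (no result reported). Compound 3 `CCNC(=O)c1noc(-c2cc(C(C)C)c(O)cc2O)c1-c1cc(CNC(C)C)no1`, which carries isopropylamino, gives 38 nM, the higher of the two available numbers.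

Compound 4 `CCNC(=O)c1noc(-c2cc(C(C)C)c(O)cc2O)c1-c1cc(CN2CCCCC2)no1` has not yet been measured. It differs from compound 3 at that same place: piperidin-1-yl in place of isopropylamino on a saturated chain carbon bound to an aromatic carbon. In words, piperidin-1-yl stands in place of isopropylamino, so a group with no ring gives way to one with a six-membered non-aromatic ring.

Going by the values given here, only one measured step bears on this change, and it does so indirectly. The data show a 7.6-fold higher number from compound 1 to compound 3 (0.88 log units; beyond the scatter), a modest step beyond the scatter, but that step replaced hydroxy rather than one nitrogen-bearing group with another. Among the compounds with values here, no measured pair shows such an exchange, so the direction of any shift remains open. The expected result is a 1.1-fold higher number from compound 3 to compound 4 (0.02 log units; within the scatter), an estimated step that stays within the scatter. Compound 4 is estimated at 40 nM, with an expected range from 15 nM to 110 nM.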

Compound 4, half-maximal inhibitory concentration: 62 nM
Compound 4: middle estimate off by 1.6-fold (0.19 log units), on the low side; the measured number falls inside the stated range.
By their numbers in this assay, from the lowest: compound 1; then compounds 3 and 4 (each within the scatter of the next).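

In this assay, going by these compounds alone, the step of a 1.6-fold higher number from compound 3 to compound 4 (0.21 log units; within the scatter) is the first measured exchange of one nitrogen-bearing group for another at this saturated chain carbon bound to an aromatic carbon, and it leaves compound 3 and compound 4 indistinguishable, even though isopropylamino has no ring and 1 hydrogen-bond donor while piperidin-1-yl has a six-membered non-aromatic ring and 0 hydrogen-bond donors. The step of a 12-fold higher number from compound 1 to compound 4 (1.09 log units; beyond the scatter) is large and beyond the scatter, so among the compounds with numbers, both nitrogen-bearing groups stand apart from the hydroxy of compound 1, and neither goes against this. Nothing available explains either the match between these two groups or their gap from hydroxy.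

Going by these compounds, whether this holds for other groups at the same place remains open, such as an unsubstituted amine, morpholin-4-yl, a carboxylic acid or a longer chain ending in an amine. Steps to or from compound 2 cannot be read, so its ether-linked amide side chain adds nothing to the comparison.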